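Thiophen-2-yl in place of 4-(methylsulfanyl)phenyl

This account rests on a few compounds, and the source may have more. Where it says the series, first, only, none or still open, it means among the compounds named here.

In a functional assay on U-87MG ATCC cells for inhibition, with U-87 MG (Homo sapiens) as the target, read by MTT assay, with a stated time of 48 h (a higher number here means a weaker inhibitor, a lower number a stronger inhibitor), compound 3 `CSc1ccc(-c2nc3ccccn3c2Sc2ccccc2)cc1` gives 26900 nM, the lowest of the two actual numbers in this set. Compound 1 `CCc1ccc(-c2nc3ccccn3c2Sc2ccccc2)cc1` gives 61700 nM. Compound 2 `COc1ccc(-c2nc3ccccn3c2Sc2ccccc2)cc1` gives > 100000 nM, which is a limit of the assay. Compound 4 `c1ccc(Sc2c(-c3cccs3)nc3ccccn23)cc1` carries thiophen-2-yl in place of 4-(methylsulfanyl)phenyl on an aromatic carbon. For the measured compounds named here, no measured step replaces the whole aryl group, so the evidence is indirect. The nearest guides are a 2.3-fold lower number from compound 1 to compound 3 (0.36 log units; beyond the scatter) and an at least 3.7-fold lower number from compound 2 to compound 3 (0.57 log units; beyond the scatter), both changes to the group that compound 4 loses. A modest move to a higher number in this assay is therefore expected, giving an expected 1.9-fold higher number from compound 3 to compound 4 (0.27 log units; within the scatter). Compound 4 is estimated at 50000 nM, with an expected range of 15000 nM to 100000 nM.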

Compound 4, half-maximal inhibitory concentration: > 100000 nM
Compound 4: only a limit was reported; the forecaster's own chance of this, stated with the estimate: 25%; middle value at least 2.0-fold (0.30 log units) from the limit.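

In this assay compound 4 gives > 100000 nM, which is a limit of the assay and not a number. Exchanging the whole aryl group at this position gives an at least 3.7-fold higher number from compound 3 to compound 4 (0.57 log units; beyond the scatter), and an at least 1.6-fold higher number from compound 1 to compound 4 (0.20 log units; that floor lies within the scatter), so thiophen-2-yl is firmly separated only from 4-(methylsulfanyl)phenyl. The step between compound 2 and compound 4 cannot be read, and the upper end of the series is now crowded: the limit of > 100000 nM in this assay, at which 2 of the 4 values shown sit.

Open, going by these compounds, is what actual numbers lie behind the two limits. Also open, on these data alone, is whether a phenyl ring carrying an amine, a carboxylic acid or a longer chain such as propyl would fall under the number of compound 3.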